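Compound 2 to compound 4: pentyl replaced by ethynyl

The source may report more compounds than this note shows. Statements on the series, on what has been measured and on what is new or still open speak of the compounds shown alone.

Values in a functional assay on HEL cells (Homo sapiens) for cytotoxicity; a higher number here means that more compound is tolerated, a lower number that less compound is tolerated:
compound 1 `CCCCCCc1cc2cn([C@H]3C[C@H](O)[C@@H](CO)O3)c(=O)nc2o1`: > 200000 nM
compound 2 `CCCCCCCCc1cc2cn([C@H]3C[C@H](O)[C@@H](CO)O3)c(=O)nc2o1`: > 50000 nM
compound 3 `C=CCCCc1cc2cn([C@H]3C[C@H](O)[C@@H](CO)O3)c(=O)nc2o1`: > 200000 nM

All three entries are limits, not numbers. Compound 2 stands only at a limit: the limit of > 50000 nM in this assay, at which 1 of the 3 values shown sits. The other two, compound 1 and compound 3, stand at a different limit: the limit of > 200000 nM in this assay, at which 2 of the 3 values shown sit.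

Compound 4 `C#CCCCc1cc2cn([C@H]3C[C@H](O)[C@@H](CO)O3)c(=O)nc2o1` differs from compound 2 as follows: ethynyl in place of pentyl on a saturated chain carbon, three bonds along the chain from an aromatic carbon. In words, this is ethynyl in place of pentyl on a saturated chain carbon, three bonds along the chain from an aromatic carbon.

The closest measured evidence is a step that the two limits leave unreadable from compound 2 to compound 3, with vinyl in place of pentyl at the same place. The other two measured steps are a step that the two limits leave unreadable from compound 1 to compound 3 and a step that the two limits leave unreadable from compound 1 to compound 2. None of the three has a readable size, so none supplies a size or direction for the new step in this assay. The expectation rests mainly on compound 3, whose limit is > 200000 nM. A limit is again the likely report for compound 4.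

The estimated step, with no direction expected to be readable, is a step that the limit leaves unreadable from compound 2 to compound 4. Compound 4 is expected at 200000 nM, with an estimated range from 50000 nM to 400000 nM.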

Compound 4, half-maximal cytotoxic concentration: > 200000 nM
Compound 4: only a limit was reported (the forecaster's own chance of this, stated with the estimate: 90%); the middle value lies on the limit itself.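

In this assay compound 4 gives > 200000 nM, which is a limit and not a number. Going by these compounds alone, compound 1, compound 2 and compound 3 also stand only at limits, so no step to compound 4 can be read. The compounds shown leave open whether ethynyl differs at all from vinyl, propyl or pentyl at this place.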